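Cyclopentyl on the aminopyrimidine: cytotoxicity outlook for compound 4

A few compounds are considered here, and "the series" means these few. Any claim that something is new, unique, unknown or untested is made for them only; others in the source may bear on it.

Measured in an ADME assay on Vero cells (Chlorocebus sabaeus) for cytotoxicity; a higher number here means that more compound is tolerated, a lower number that less compound is tolerated:
compound 1 `Nc1nc(-c2c(-c3ccc(F)cc3)nn3c(NC4CCCC4)cccc23)c[nH]1`: "not determined" (no result reported)
compound 2 `Nc1nccc(-c2c(-c3ccc(F)cc3)nn3c(NC4CCCC4)cccc23)n1`: 46000 nM
compound 3 `Fc1ccc(-c2nn3c(NC4CCCC4)cccc3c2-c2cccnc2)cc1`: reported only as a limit, > 40000 nM

Among the measured compounds shown here, compound 2 stands as the only plain number in this assay; compound 3 gives a limit and compound 1 gives nothing. For the measured compounds named here, the single measured step, a step that the limit leaves unreadable from compound 2 to compound 3, has no readable size because of the limit of > 40000 nM in this assay, at which 1 of the 3 values shown sits.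

Compound 4 `Fc1ccc(-c2nn3c(NC4CCCC4)cccc3c2-c2ccnc(NC3CCCC3)n2)cc1` differs from compound 2 by cyclopentyl in place of hydrogen on a nitrogen on an aromatic ring. Going by the values given here, no measured step bears on this change: the step from compound 2 to compound 3 concerns another position and is unreadable. Expected is a step of a 1.2-fold lower number from compound 2 to compound 4 (0.06 log units; within the scatter), not beyond the scatter. For compound 4 the estimate is 40000 nM, with a range from 15000 nM to 100000 nM.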

Compound 4, half-maximal cytotoxic concentration: > 160000 nM
Compound 4 was reported as a limit; the forecaster's own chance of this, stated with the estimate: 40%; middle value at least 4.0-fold (0.60 log units) away from the limit.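

Compound 4 is reported in this assay only as a limit, > 160000 nM. Cyclopentyl in place of hydrogen on a nitrogen on an aromatic ring gives an at least 3.4-fold higher number from compound 2 to compound 4 (0.54 log units; beyond the scatter), the first readable step in this series. Among the compounds shown here, the change from amino to cyclopentylamino therefore moves this read-out towards more compound tolerated, a direction the earlier compounds could not show.

The full size of this step stays unread because compound 4 ends at a limit: the limit of > 160000 nM in this assay, at which 1 of the 4 values shown sits. Going by these compounds, whether methylamino or a longer chain ending in a carboxylic acid at this nitrogen moves the read-out the same way remains open.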